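Cyclopropyl for Ethyl on a Second Core

The compounds below may be only part of what the source reports. "The series", "measured", "known", "first", "only" and "open" are said of these compounds alone.

Of the compounds shown here, three have been measured in an ADME assay on liver (Mus musculus) for metabolic stability, read by LC-MS, using microsomes and NADPH; a lower number here means that less of the compound is left, a higher number that more of the compound is left. Compound 1 `CCCN(Cc1ccc(OCCN2C(=O)CCC2=O)c(C)c1)[C@@H](CC(=O)O)c1ccc(Cl)cc1` is one of them; compound 2 `Cc1cc(CN(CC2CC2)[C@@H](CC(=O)O)c2ccc(Cl)cc2)ccc1OCCN1C(=O)CCC1=O` is its partner, and the two differ by a single change, (cyclopropyl in place of ethyl on a saturated chain carbon bound to an amine nitrogen). In this assay compound 1 gives 97%, and compound 2 gives 87%, so that a number 10 percentage points lower from compound 1 to compound 2 (within the scatter). Compound 3 `CCCN(Cc1ccc(OCCn2c(=O)ccn(C)c2=O)c(OC)c1)C(CC(=O)O)c1ccc(Cl)cc1` belongs to a second core; how that core differs from the core of compound 1 is not broken down here. In this assay compound 3 gives 50%, the lowest of the three numbers, and its gap to both compound 1 and compound 2 lies beyond the scatter.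

Compound 4 `COc1cc(CN(CC2CC2)C(CC(=O)O)c2ccc(Cl)cc2)ccc1OCCn1c(=O)ccn(C)c1=O` is the unmeasured partner of compound 3, related to it by the same change that links compound 1 and compound 2: cyclopropyl in place of ethyl on a saturated chain carbon bound to an amine nitrogen. Among the compounds with values here, the only guide to the size of the step from compound 3 to compound 4 is the earlier pair, where the step stayed within the scatter. Because a number 10 percentage points lower from compound 1 to compound 2 (within the scatter), the step is expected to be small here as well, a number 5 percentage points lower from compound 3 to compound 4 (within the scatter). Compound 4 is therefore estimated at 45% in this assay, with an expected range from 30% to 62%, kept wide since the second core offers only one measured point.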

Compound 4, percent of the compound remaining: 42%
Compound 4: middle estimate off by 3 percentage points, on the high side; the measured number falls inside the stated range.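

In this assay, putting cyclopropyl in place of ethyl on a saturated chain carbon bound to an amine nitrogen gives, on the second core, a number 8 percentage points lower from compound 3 to compound 4 (within the scatter). Set beside the earlier pair, the change looks the same on both cores: the same change on two cores in this assay, a number 10 percentage points lower (within the scatter) from compound 1 to compound 2 and a number 8 percentage points lower (within the scatter) from compound 3 to compound 4, 2 percentage points apart, within the scatter of two such steps This shows that, for these two pairs, the change carries over from one core to the other without a step that stands out from repeated measurements, even though the numbers on the second core lie much lower; it does not show that the change has a real effect of its own, since neither step can be told from scatter, and two cores are too few to set a rule for the whole series.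

The compounds shown leave open whether a larger ring such as cyclobutyl, or a longer chain such as butyl, would fit the same pattern in this assay if placed on that amine nitrogen. They also leave open whether the same swap would stay this small on a core carrying a primary amide in place of the carboxylic acid.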